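This account rests on a few compounds, and the source may have more. Where it says the series, first, only, none or still open, it means among the compounds named here.

Compound 1 `COc1cccc(-c2nc3cccc(-c4cc(OC)c(OC)c(OC)c4)c3o2)c1` sits at the upper edge of the numbers shown: in a functional assay on NCI-H460 cells (Homo sapiens) for antiproliferative activity, read by MTT assay, with a stated time of 48 h (on this read-out higher numbers stand for weaker inhibition and lower numbers for stronger inhibition), compound 1 gives > 25000 nM, which is a limit of the assay and not a number. Going by the values given here, compound 2 `COc1cc(-c2cccc3nc(-c4cccc(Br)c4)oc23)cc(OC)c1OC` is the only member of the set with a measured number, giving 3800 nM in this assay. Compound 3 `COc1cc(-c2cccc3nc(-c4ccc(Br)cc4)oc23)cc(OC)c1OC` returns > 25000 nM in this assay, again a limit and not a number, so that the limit of > 25000 nM in this assay, at which 2 of the 3 values shown sit, holds for two of the three compounds.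

Compound 4 `COc1cc(-c2cccc3nc(-c4ccc(C)cc4)oc23)cc(OC)c1OC` is the unmeasured member. It differs from compound 1 in one place: 4-methylphenyl in place of 3-methoxyphenyl on an aromatic carbon. Among the measured steps, the one from compound 1 to compound 3 is the closest relative, since it also places a substituent on the 4-position of the phenyl ring, but that step is a step that the two limits leave unreadable from compound 1 to compound 3 and therefore unreadable. The step of an at least 6.5-fold higher number from compound 2 to compound 3 (0.81 log units; beyond the scatter) shows that moving bromo from the 3-position to the 4-position costs potency, while an at least 6.5-fold lower number from compound 1 to compound 2 (0.81 log units; beyond the scatter) shows a gain when bromo replaces methoxy. A 4-methylphenyl group resembles the weak 4-bromophenyl case more than the active 3-bromophenyl one, so compound 4 is expected to remain near the limit, with a step of a number no higher from compound 1 to compound 4 (the limit leaves the size open) expected from compound 1 to compound 4 and an estimated value of 25000 nM (range 7000 nM to 80000 nM).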

Compound 4, half-maximal inhibitory concentration: 1900 nM
For compound 4 the middle estimate is 13-fold (1.12 log units) above the measured one; the measured number lies below the stated range.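

In this assay, the weak 4-bromophenyl case had left it possible that only the 3-bromophenyl group keeps activity at this carbon, but the 4-methylphenyl group rules that reading out, giving an at least 13-fold lower number from compound 3 to compound 4 (1.11 log units; beyond the scatter) when methyl takes the place of bromo on the same phenyl ring. The change from the 3-methoxyphenyl group gives an at least 13-fold lower number from compound 1 to compound 4 (1.11 log units; beyond the scatter), and the comparison with the 3-bromophenyl group gives a 2.0-fold lower number from compound 2 to compound 4 (0.30 log units; within the scatter), so activity at this carbon does not depend on a bromo substituent, and these two compounds cannot be ranked. As far as these compounds go, the true size of the two large steps remains open, as each starts from a value that is a limit and not a number: the limit of > 25000 nM in this assay, at which 2 of the 4 values shown sit.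

The compounds shown leave open whether other groups on this phenyl ring, such as a 4-methoxyphenyl, a 4-aminophenyl or a 4-carboxyphenyl group, would behave like the 4-methylphenyl group or like the 4-bromophenyl group. They also leave open whether a 3-methylphenyl group would match the 3-bromophenyl group, and they do not explain why methyl and bromo part so sharply on the same ring.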